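The compounds below may be only part of what the source reports. "The series", "measured", "known", "first", "only" and "open" are said of these compounds alone.

Measured compounds in an ADME assay for permeability, using PAMPA, with a stated time of 30 min, at pH 7.4; a lower number here means that the compound crosses the layer more slowly, a higher number that the compound crosses the layer faster:

compound 1 `COc1ccccc1Oc1ccc2c(NCCCNCc3ccco3)ccnc2c1` gives 317 10^-6 cm/s
compound 2 `COc1cccc(Oc2ccc3c(NCCCNCc4cc(F)ccc4OC)ccnc3c2)c1` gives 317 10^-6 cm/s
compound 3 `COc1cccc(CNCCCNc2ccnc3cc(Cc4ccccc4)ccc23)c1O` gives 23 10^-6 cm/s

Compound 3 stands lowest of the three numbers. Compound 1 and compound 2 both sit well above it, and both gaps are beyond the scatter. Compounds 1 and 2 give the same number in this assay, so between them no order can be read.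

Compound 4 `COc1cccc(CNCCCNc2ccnc3cc(Oc4ccccc4)ccc23)c1O` is not yet measured. It differs from compound 3 in one place: phenoxy in place of benzyl on an aromatic carbon. For the measured compounds named here, no step between measured compounds isolates this change. Compounds 1 and 2 carry a phenoxy on the shared core and stand high; compound 3 carries a benzyl there and stands low; but compound 3 also differs from both in the chain attached to the core, so the phenoxy alone cannot be credited with the gap.

The expectation for compound 4 is an upward step in this assay, a 2.6-fold higher number from compound 3 to compound 4 (0.42 log units; beyond the scatter), beyond the scatter but not reaching the numbers of compounds 1 and 2. Compound 4 is thus estimated at 60 10^-6 cm/s, with a range from 20 10^-6 cm/s to 180 10^-6 cm/s.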

Compound 4, apparent permeability: 317 10^-6 cm/s
Beside the measured number, compound 4's estimate is 5.3-fold (0.72 log units) below it, outside the stated range (above it).
By their numbers in this assay, from the lowest: compound 3; then compounds 1, 2 and 4 (each within the scatter of the next).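

In this assay, phenoxy in place of benzyl on this aromatic carbon gives a 14-fold higher number from compound 3 to compound 4 (1.14 log units; beyond the scatter), a large step with the chain attached to the core unchanged. The earlier compounds shown here could not separate the group at this place from the chain, whereas this pair shows that the group at this place can by itself move the read-out by that much, even though the two groups match in 7 heavy atoms and in their six-membered aromatic ring of carbon only. No measurement shown here accounts for the step.

Still open, from the compounds shown here alone, is whether the oxygen of the phenoxy is what matters, which a sulfur bridge, an amine bridge or a carbonyl bridge to the same phenyl ring at this aromatic carbon would test against the benzyl and phenoxy pair. Also open, going by these compounds, is whether the same exchange gives a step of this size with a different chain on the core, such as the furan-bearing chain of compound 1 or a longer chain.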